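The compounds below may be only part of what the source reports. "The series", "measured", "known", "first", "only" and "open" are said of these compounds alone.

- Compound 1 `Cc1c(-c2cncc(-c3ccc(OC(F)(F)F)cc3)c2)[nH]c2ccccc2c1=O`: 140000 nM
- Compound 2 `COc1ccc2c(=O)c(C)c(-c3cncc(-c4ccc(Cl)c(Cl)c4)c3)[nH]c2c1`: 15000 nM
- Compound 3 `COc1ccc2c(=O)c(C)c(-c3ccnc(-c4ccc(OC(F)(F)F)cc4)c3)[nH]c2c1`: 120000 nM

All values come from a physicochemical assay for solubility, in phosphate buffer, measured as kinetic solubility, at pH 1, tested at 200 uM; a lower number here means a less soluble compound, a higher number a more soluble compound. Compound 1 and compound 3 share the top of this small set, within the scatter of each other, while compound 2 lies lower than compound 1, beyond the scatter.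

Compound 4 `COc1ccc2c(=O)c(C)c(-c3cncc(-c4ccc(OC(F)(F)F)cc4)c3)[nH]c2c1` has methoxy in place of hydrogen on an aromatic carbon of the core of compound 1 (methoxy in place of hydrogen on an aromatic carbon). Within the data shown here, no measured pair isolates this change. Compound 3, which also carries methoxy, gives 120000 nM, and compound 2, also with methoxy, gives 15000 nM. A small downward step in this assay is therefore expected, possibly none beyond the scatter. The estimated step runs a 1.6-fold lower number from compound 1 to compound 4 (0.22 log units; within the scatter). For compound 4 the estimate is 85000 nM, with an expected range from 25000 nM to 170000 nM.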

Compound 4, solubility: 7800 nM
The estimate for compound 4 lay 11-fold (1.04 log units) above the measured number; the measured number lies below the stated range.
By their numbers in this assay, from the lowest: compounds 4 and 2 (each within the scatter of the next); then compounds 3 and 1 (each within the scatter of the next).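

Methoxy in place of hydrogen on an aromatic carbon of the core, at the place meta to a fused ring and para to a fused ring, gives in this assay an 18-fold lower number from compound 1 to compound 4 (1.25 log units; beyond the scatter) as the first step in the series that isolates a single change. Among these compounds, the earlier methoxy compounds had no hydrogen counterpart, so this large effect of the change could not be read from them. Nothing at hand accounts for the step.

From the compounds shown here alone, whether the step belongs to methoxy itself or to this position stays open, as no fluorine, hydroxyl or amine stands here and methoxy stands on no other carbon of the core. Whether it carries over to the other substituents of compound 2 and compound 3 cannot be read.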